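Pentafluorosulfanyl for dimethylamino on the benzamide ring

The compounds below may be only part of what the source reports. "The series", "measured", "known", "first", "only" and "open" are said of these compounds alone.

Measured compounds:
compound 1 `CN(C)c1ccc(C(=O)NCc2ccc(NS(C)(=O)=O)cc2Cl)cc1`: 0.883 h
compound 2 `CC(C)(O)c1ccc(C(=O)NCc2ccc(NS(C)(=O)=O)cc2Cl)cc1`: 20.2 h
compound 3 `CS(=O)(=O)Nc1ccc(CNC(=O)c2ccc(C(F)(F)C(F)(F)F)cc2)c(Cl)c1`: 1.6 h

In an ADME assay on microsomes from liver (Rattus norvegicus, strain Sprague-Dawley) for metabolic stability, read by HPLC, using NADPH, with stated times of 5 min and 60 min, tested at 10 uM (on this read-out lower numbers stand for a shorter-lived compound and higher numbers for a longer-lived compound), compound 1 gives 0.883 h, the lowest of the three numbers. Its nearest neighbour is compound 3, which in this assay gives 1.6 h; the furthest is compound 2, which gives 20.2 h.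

The step under consideration leads to compound 4 `CS(=O)(=O)Nc1ccc(CNC(=O)c2ccc(S(F)(F)(F)(F)F)cc2)c(Cl)c1`, not yet measured. The change from compound 1 is a group of 6 heavy atoms (5 fluorine, 1 sulfur; no ring) in place of a group of 3 heavy atoms (2 carbon, 1 nitrogen; no ring), on an aromatic carbon

Two measured steps start from compound 1 and replace the dimethylamino group. The step of a 23-fold higher number from compound 1 to compound 2 (1.36 log units; beyond the scatter) is large; the step of a 1.8-fold higher number from compound 1 to compound 3 (0.26 log units; within the scatter) stays within the scatter. The group entering in compound 4 has no hydrogen-bond donor or acceptor and, like the pentafluoroethyl of compound 3, carries fluorine, whereas the 1-hydroxy-1-methylethyl of compound 2 brings a donor. The closer analogy is therefore compound 3, and a step in this assay of no more than modest size is expected, if anything upward.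

Compound 4 is therefore expected to give 1.5 h, between 0.6 h and 5 h, which would be a step of a 1.7-fold higher number from compound 1 to compound 4 (0.23 log units; within the scatter).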

Compound 4, half-life: 2.3 h
Compound 4: the middle estimate sits 1.5-fold (0.19 log units) below what was measured; measured number inside the range.
By their numbers in this assay, from the lowest: compounds 1, 3 and 4 (each within the scatter of the next, the first and the last beyond it); then compound 2.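

In this assay, the pentafluorosulfanyl group on this aromatic carbon gives the first fluorine-bearing replacement of dimethylamino that clears the scatter: a 2.6-fold higher number from compound 1 to compound 4 (0.42 log units; beyond the scatter), whereas compound 3 stayed within it. The two fluorine-bearing groups still cannot be told apart here, with a 1.4-fold higher number from compound 3 to compound 4 (0.16 log units; within the scatter), so the gain over compound 1 is small and a difference between pentafluoroethyl and pentafluorosulfanyl is not shown; 1-hydroxy-1-methylethyl remains well ahead, with an 8.8-fold lower number from compound 2 to compound 4 (0.94 log units; beyond the scatter). Nothing in the data available on this series bears on why these groups differ.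

Open, as far as these compounds go, is whether the long half-life of compound 2 depends on its hydroxyl, which a tert-butyl group at the same place on the ring would test directly, and whether a smaller group such as trifluoromethyl would fall with compounds 3 and 4. Also open, from the compounds shown here alone, is whether the ranking of these groups holds on the shared core when the chlorine or the methanesulfonamide is changed, as all four compounds carry both unchanged.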